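The source may hold more compounds than are shown below. What is called first, only, known or untested is meant among the compounds shown, and "the series" means these compounds.

Values so far in an ADME assay on J774.A1 cells (Mus musculus) for cytotoxicity, read by MTT assay, with a stated time of 72 h (a higher number here means that more compound is tolerated, a lower number that less compound is tolerated), by compound

compound 1 `COc1ccc(-c2cc(-c3ccc(C4NC(=O)c5ccccc5N4)cc3)nc(N)n2)cc1` gives 178000 nM
compound 2 `Nc1nc(-c2ccccc2)cc(-c2ccc(C3NC(=O)c4ccccc4N3)cc2)n1` gives "not determined" (no result reported)
compound 3 `CN1CCN(c2ccc(-c3cc(-c4ccc(C5NC(=O)c6ccccc6N5)cc4)nc(N)n3)cc2)CC1` gives 10200 nM

Compound 3 at 10200 nM holds the lower of the two numbers available, and compound 2 supplies no number to compare. The next step leads to compound 4 `Nc1nc(-c2ccc(Br)cc2)cc(-c2ccc(C3NC(=O)c4ccccc4N3)cc2)n1` and makes this change (bromo in place of 4-methylpiperazin-1-yl on an aromatic carbon) with bromo in place of 4-methylpiperazin-1-yl on an aromatic carbon, para to a large group.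

Going by the values given here, only one measured step bears on this change. Putting 4-methylpiperazin-1-yl in place of methoxy gave a 17-fold lower number from compound 1 to compound 3 (1.24 log units; beyond the scatter) and this large step lies beyond the scatter. Compound 4 likewise lacks 4-methylpiperazin-1-yl, so a large step to a higher number is expected in this assay for it, close to a reversal of that step. Bromo is not methoxy, however, and no measured compound carries bromo. The expectation therefore rests on a single step, and the range is kept wide. The estimated change is a 7.8-fold higher number from compound 3 to compound 4 (0.89 log units; beyond the scatter) and it would lie short of a full reversal. For compound 4 the estimate is 80000 nM with an expected range from 25000 nM to 250000 nM in this read-out.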

Compound 4, half-maximal cytotoxic concentration: 125000 nM
The estimate for compound 4 lay 1.6-fold (0.19 log units) below the measured number; the measured number falls inside the stated range.
By their numbers in this assay, from the lowest: compound 3; then compounds 4 and 1 (each within the scatter of the next).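

In this assay, bromo in place of 4-methylpiperazin-1-yl on this aromatic carbon gives a large step (a 12-fold higher number from compound 3 to compound 4 (1.09 log units; beyond the scatter)), so a second replacement of 4-methylpiperazin-1-yl now moves the number beyond the scatter. Bromo in place of methoxy at the same position stays within the scatter (a 1.4-fold lower number from compound 1 to compound 4 (0.15 log units; within the scatter)), so among compounds 1, 3 and 4 only compound 3, the one carrying 4-methylpiperazin-1-yl, stands apart from the others, while bromo and methoxy cannot be told apart here. No supporting data bear on why the number shifts with this change.

Compound 2, with no group at this position, has no number in this assay, so any step to or from it cannot be read. Going by these compounds, it remains open whether the lower number of compound 3 follows the six-membered ring or its nitrogens: morpholin-4-yl, dimethylamino or a carboxylic acid at this position would test that, and the present set holds none of these groups.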